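This account rests on a few compounds, and the source may have more. Where it says the series, first, only, none or still open, it means among the compounds named here.

Measured so far in a functional assay on MDA-MB-231 cells (Homo sapiens) for cytotoxicity, read by MTT assay, with a stated time of 96 h; a lower number here means a stronger inhibitor, a higher number a weaker inhibitor

compound 1 `CC[C@H](N)C(=O)N[C@@H]1C(=O)N2[C@@H](CC[C@@H]1CNC(=O)NCc1ccccc1)CC[C@H]2C(=O)NC(c1ccccc1)c1ccccc1` gives 3400 nM
compound 2 `CC[C@H](NC)C(=O)N[C@@H]1C(=O)N2[C@@H](CC[C@@H]1CCN)CC[C@H]2C(=O)NC(c1ccccc1)c1ccccc1` gives 2300 nM

Compound 1 has the higher of the two numbers, but the gap to compound 2 lies within the scatter, so the pair cannot be ranked. Among the compounds with values here, no step between measured compounds that differ in one place is available, and the data hold no direct precedent for the change under review.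

The next compound is compound 3 `CC[C@H](N)C(=O)N[C@@H]1C(=O)N2[C@@H](CC[C@@H]1CCO)CC[C@H]2C(=O)NC(c1ccccc1)c1ccccc1`, not yet measured. Compared with compound 1, it carries hydroxymethyl in place of (benzylcarbamoyl)amino on a saturated chain carbon bound to a saturated ring carbon and keeps the rest of the structure. The same difference, cut one bond further out, reads ((benzylcarbamoyl)amino)methyl to 2-hydroxyethyl.

Within the data shown here, the only guide is that compound 1 at 3400 nM and compound 2 at 2300 nM sit close together, which gives no reason to expect a move in either direction. The expected step of a 1.0-fold higher number from compound 1 to compound 3 (0.01 log units; within the scatter) in this assay is none beyond the scatter, though this expectation is weakly supported. Compound 3 is estimated at 3500 nM with an expected range from 1200 nM to 11000 nM in this series.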

Compound 3, half-maximal inhibitory concentration: 1800 nM
Compound 3: middle estimate off by 1.9-fold (0.29 log units), on the high side, and the stated range covers the measured number.
By their numbers in this assay, from the lowest: compounds 3, 2 and 1 (each within the scatter of the next).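

In this assay the change at this position, on a saturated chain carbon bound to a saturated ring carbon, gives a 1.9-fold lower number from compound 1 to compound 3 (0.28 log units; within the scatter) and so leaves the two compounds unranked. Within the data shown here, this is the first step between compounds that differ in one place, and it shows that (benzylcarbamoyl)amino, with 11 heavy atoms and a six-membered aromatic ring, can give way to hydroxymethyl, with 2 heavy atoms and no ring, without a step beyond the scatter. No measurement at hand bears on the reason for this result.

Still open, going by these compounds, is how a carboxylic acid, a methyl ether or a longer chain such as 3-hydroxypropyl would read at this place, and whether any group there gives a step beyond the scatter. Compound 2 differs from compound 3 in more than one place, so the amine on the chain of compound 2 cannot be compared directly with the hydroxyl of compound 3, and a one-place pairing of those two groups remains to be seen.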